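This account rests on a few compounds, and the source may have more. Where it says the series, first, only, none or still open, it means among the compounds named here.

Measured so far:
compound 1 `Cc1cc(Nc2ccn(Cc3cccc4ccccc34)n2)n2nc(SCc3ccc(Br)cc3)nc2n1` gives 4310 nM
compound 2 `Cc1cc(Nc2cc(-c3ccccc3)[nH]n2)n2nc(SCc3ccc([N+](=O)[O-])cc3)nc2n1` gives 5060 nM

Both numbers come from a functional assay on MCF7 cells (Homo sapiens) for inhibition, read by MTT assay, with a stated time of 72 h; on this read-out lower numbers stand for stronger inhibition and higher numbers for weaker inhibition. In this assay compound 1 gives 4310 nM and compound 2 gives 5060 nM; the two values lie within the scatter of each other, so compound 1 is not set apart from compound 2 on this read-out. Within the data shown here, the two structures differ in more than one place, so no single step between them is counted.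

Compound 3 `Cc1cc(Nc2ccn(Cc3ccc(F)cc3)n2)n2nc(SCc3ccc(Br)cc3)nc2n1` has not yet been measured. It differs from compound 1 in one place: 4-fluorophenyl in place of naphthalen-1-yl on a saturated chain carbon bound to an aromatic nitrogen. Among the measured compounds shown here, no measured pair isolates a change of this kind, so the size of the step has to be estimated without a precedent. The step of a 1.3-fold higher number from compound 1 to compound 3 (0.11 log units; within the scatter) is expected to stay within the scatter, leaning if anything toward weaker inhibition. Compound 3 is therefore estimated at 5500 nM, with a range from 2500 nM to 12000 nM.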

Compound 3, half-maximal inhibitory concentration: 4280 nM
For compound 3 the middle estimate is 1.3-fold (0.11 log units) above the measured one; the measured number falls inside the stated range.
By their numbers in this assay, from the lowest: compounds 3, 1 and 2 (each within the scatter of the next).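

In this assay, the step of a 1.0-fold lower number from compound 1 to compound 3 (0.00 log units; within the scatter) comes with 4-fluorophenyl in place of naphthalen-1-yl on a saturated chain carbon bound to an aromatic nitrogen. Among these compounds, this is the first one-place comparison, and it shows that at this position, going from two six-membered aromatic rings and 10 heavy atoms to one ring carrying fluorine and 7 heavy atoms does not separate the two compounds on this read-out. Nothing available explains this result.

Going by these compounds, removing a ring and adding fluorine occur in one step, so the part played by each remains open. Also open, on these data alone, is whether a group other than an aromatic ring at this position, such as an amine or a carboxylic acid, or a longer chain in place of the single saturated carbon, would read the same.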